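The compounds below may be only part of what the source reports. "The series", "measured", "known", "first", "only" and "open" are said of these compounds alone.

In a functional assay on MCF7 cells (Homo sapiens) for cytotoxicity, read by MTT assay, with a stated time of 72 h (on this read-out higher numbers stand for weaker inhibition and lower numbers for stronger inhibition), compound 3 `Cc1cccc(Nc2ncnc3oc(C)c(C(=O)O)c23)c1` gives 57500 nM and lies within the scatter of compound 1 `Cc1oc2ncnc(Nc3cccc(Br)c3)c2c1C(=O)O` at 68000 nM on this read-out. Compound 2 `Cc1oc2ncnc(Nc3cccc(Cl)c3)c2c1C(=O)NC(C)C` gives 191000 nM as a higher number than either of them.

The next structure is compound 4 `Cc1oc2ncnc(Nc3cccc(Cl)c3)c2c1C(=O)O`, reached from compound 3 through chloro in place of methyl on an aromatic carbon with chloro in place of methyl on an aromatic carbon, so 3-methylphenyl becomes 3-chlorophenyl. Among the compounds with values here, the one measured change at this place is a 1.2-fold lower number from compound 1 to compound 3 (0.07 log units; within the scatter) for methyl in place of bromo on an aromatic carbon, and it stays within the scatter. Compound 2 also carries 3-chlorophenyl, but it is an amide where compound 4 is a carboxylic acid, so it offers no clean comparison.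

On that single small step, no change beyond the scatter is expected in this assay and no direction is favoured. The expected change is a 1.1-fold higher number from compound 3 to compound 4 (0.03 log units; within the scatter) and remains within the scatter. For compound 4 the estimate is 62000 nM with an expected range from 35000 nM to 110000 nM for repeated measurements.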

Compound 4, half-maximal inhibitory concentration: 57500 nM
Beside the measured number, compound 4's estimate is 1.1-fold (0.03 log units) above it; the measured number falls inside the stated range.
By their numbers in this assay, from the lowest: compounds 3, 4 and 1 (each within the scatter of the next); then compound 2.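

In this assay chloro in place of methyl gives no change at the digits printed from compound 3 to compound 4 (within the scatter) and chloro in place of bromo gives a 1.2-fold lower number from compound 1 to compound 4 (0.07 log units; within the scatter), so methyl, chloro and bromo at this place on the aromatic ring cannot be told apart in the carboxylic acids. Within the data shown here, compound 4 also makes the first one-place comparison with the isopropyl amide, and hydroxy in place of isopropylamino on the carbonyl carbon gives a 3.3-fold lower number from compound 2 to compound 4 (0.52 log units; beyond the scatter), a step beyond the scatter with 3-chlorophenyl held constant. Nothing measured here accounts for either result.

Going by these compounds, it remains open whether an amine or a methoxy group at this place on the aromatic ring would also stay within the scatter. The compounds shown also leave open how a primary amide or a methyl ester on the carbonyl carbon would compare with the carboxylic acid and the isopropyl amide.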